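Taking Away One Methoxy Group and Cell Growth Inhibition

This account rests on a few compounds, and the source may have more. Where it says the series, first, only, none or still open, it means among the compounds named here.

Three compounds built on one shared core differ only in the methoxy groups carried on one aromatic ring. Compound 1 `COc1cc(C=C2C(=O)N(c3ccc(Cl)cc3)N(c3ccc(Cl)cc3)C2=O)cc(OC)c1OC` carries three of them. In a functional assay on SMMC-7721 cells (Homo sapiens) for cytotoxicity, read by MTT assay, with a stated time of 72 h (on this read-out higher numbers stand for weaker inhibition and lower numbers for stronger inhibition), compound 1 gives 29500 nM. Compound 2 `COc1ccc(C=C2C(=O)N(c3ccc(Cl)cc3)N(c3ccc(Cl)cc3)C2=O)cc1OC` has one fewer: hydrogen in place of methoxy on an aromatic carbon. For compound 2 the result in this assay is a limit, > 128000 nM, and not a number, which is why the step of an at least 4.3-fold higher number from compound 1 to compound 2 (0.63 log units; beyond the scatter) can only be given as a bound (the limit of > 128000 nM in this assay, at which 1 of the 3 values shown sits). Compound 3 `COc1cccc(C=C2C(=O)N(c3ccc(Cl)cc3)N(c3ccc(Cl)cc3)C2=O)c1OC` also carries two methoxy groups, but the difference between its core and that of compound 1 is not broken down here. In this assay compound 3 gives 14100 nM, and the step of an at least 9.0-fold lower number from compound 2 to compound 3 (0.95 log units; beyond the scatter) follows.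

Compound 4 `COc1ccccc1C=C1C(=O)N(c2ccc(Cl)cc2)N(c2ccc(Cl)cc2)C1=O` has not yet been measured. It differs from compound 3 by hydrogen in place of methoxy on an aromatic carbon. This is the same kind of change as from compound 1 to compound 2, though the place is not identical: in the earlier pair the carbon was also meta to a methoxy group (2 heavy atoms). Since the step of an at least 4.3-fold higher number from compound 1 to compound 2 (0.63 log units; beyond the scatter) weakened inhibition, a weakening is expected here as well, of roughly a 3.2-fold higher number from compound 3 to compound 4 (0.50 log units; beyond the scatter). The estimate for compound 4 in this assay is 45000 nM, expected to lie between 15000 nM and 130000 nM.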

Compound 4, half-maximal inhibitory concentration: 25800 nM
Beside the measured number, compound 4's estimate is 1.7-fold (0.24 log units) above it; measured number inside the range.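

In this assay, the change from 2,3-dimethoxyphenyl to 2-methoxyphenyl gives a 1.8-fold higher number from compound 3 to compound 4 (0.26 log units; within the scatter), so on this core the loss of one methoxy group leaves the two numbers within the usual scatter of each other. Set beside the earlier case, the comparison reads: the same change on two cores in this assay, an at least 4.3-fold higher number (0.63 log units; beyond the scatter) from compound 1 to compound 2 and a 1.8-fold higher number (0.26 log units; within the scatter) from compound 3 to compound 4; the limit leaves it open whether they differ. The series therefore does not show that this change carries from one core to another with the same size, nor that its size depends on the core, while an at least 4.9-fold lower number from compound 2 to compound 4 (0.69 log units; beyond the scatter) is a different swap, 2-methoxyphenyl in place of 3,4-dimethoxyphenyl, and says only that these two arrangements of methoxy groups are separated by more than the scatter.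

The compounds shown leave open how a hydroxyl group or an amine in that same place would read in this assay. They also leave open what a plain phenyl ring with no methoxy group at all would give on the shared core.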